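The source may report more compounds than this note shows. Statements on the series, on what has been measured and on what is new or still open speak of the compounds shown alone.

Measured compounds in a functional assay on HepG2 cells (Homo sapiens) for cytotoxicity, read by MTT assay, with a stated time of 48 h; on this read-out higher numbers stand for weaker inhibition and lower numbers for stronger inhibition:

Compound 1, `FC(F)=C(F)CCSc1nccs1` — in this assay compound 1 gives > 120000 nM, which is a limit of the assay and not a number.
Compound 2, `FC(F)=C(F)CCSc1ncc(-c2ccncc2)s1` — in this assay compound 2 gives > 120000 nM, again a limit of the assay.
Compound 3, `O=S(=O)(CCC(F)=C(F)F)c1ncc(-c2ccncc2)s1` — in this assay compound 3 gives > 120000 nM, also a limit of the assay.

All three values sit at the same point: the limit of > 120000 nM in this assay, at which 3 of the 3 values shown sit. Within the data shown here, the one step between measured compounds that differ in a single place is a step that the two limits leave unreadable from compound 2 to compound 1; the change behind it is hydrogen in place of pyridin-4-yl on an aromatic carbon. Because both ends are limits, nothing about the size of this step can be read.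

The unmeasured compound is compound 4, `O=S(=O)(CCC(F)=C(F)F)c1nccs1`. It is reached from compound 3 by hydrogen in place of pyridin-4-yl on an aromatic carbon. This is the same kind of change as that from compound 2 to compound 1; the two place descriptions agree except that in one case the ring atom two bonds away bears a large group and in the other a group of 8 heavy atoms. How the core of compound 3 differs from the core of compound 2 is not broken down here.

Among the measured compounds shown here, since all three measured values stop at the assay limit, and the one comparable step could not be sized, the expectation for compound 4 rests only on that shared limit. Compound 4 is expected to give 200000 nM in this assay, with a likely range from 120000 nM to 600000 nM. The step this estimate means, a step that the limit leaves unreadable from compound 3 to compound 4, is therefore expected to be essentially flat, and the most probable outcome is that compound 4, like the others, returns only a limit.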

Compound 4, half-maximal inhibitory concentration: > 120000 nM
Compound 4 was reported as a limit; the forecaster's own chance of this, stated with the estimate: 85%; the middle value is on the limit's open side.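

In this assay compound 4 gives > 120000 nM, a limit of the assay and not a number. Compound 3 also stands at a limit, so no size can be read for the step between compound 3 and compound 4: the limit of > 120000 nM in this assay, at which 4 of the 4 values shown sit. The compounds shown leave open whether any of them has a measurable value in this assay, and what hydrogen in place of pyridin-4-yl does to that value.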